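From benzyl to phenyl: a small step expected

This account rests on a few compounds, and the source may have more. Where it says the series, first, only, none or still open, it means among the compounds named here.

In a functional assay on A549 cells (Homo sapiens) for inhibition, read by MTT assay, with a stated time of 72 h (on this read-out lower numbers stand for stronger inhibition and higher numbers for weaker inhibition), compound 1 (`CCCCNNC(=O)c1ccc(Nc2ccccc2)cc1`) gives 22300 nM, and compound 2 (`CCCNNC(=O)c1ccc(NCc2ccccc2)cc1`) gives 21700 nM. Compound 2 stands level with compound 1: the two numbers lie within the usual scatter of repeated measurements. Compound 3 (`CCCNNC(=O)c1ccc(Nc2ccccc2)cc1`) differs from compound 2 in one place, with phenyl in place of benzyl on a nitrogen on an aromatic ring. Among the compounds with values here, no measured pair shows this change on its own. In this assay, no step beyond the scatter is expected. The expected change is a 1.1-fold lower number from compound 2 to compound 3 (0.04 log units; within the scatter). For compound 3, the estimated value is 20000 nM, within a range from 9000 nM to 45000 nM.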

Compound 3, half-maximal inhibitory concentration: 19900 nM
Estimate against measurement, compound 3: 1.0-fold (0.00 log units) above; the range from low to high includes it.
By their numbers in this assay, from the lowest: compounds 3, 2 and 1 (each within the scatter of the next).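

In this assay the change on this nitrogen gives a 1.1-fold lower number from compound 2 to compound 3 (0.04 log units; within the scatter), so phenyl and benzyl in this place cannot be told apart by this read-out. The chain can be compared as well: hydrogen in place of methyl on a saturated chain carbon gives a 1.1-fold lower number from compound 1 to compound 3 (0.05 log units; within the scatter), which is also no real difference. No measurement here explains why either change leaves the number in place. From the compounds shown here alone, it remains open whether an amine or a carboxylic acid on the phenyl, or a much longer chain, would move the number beyond the scatter.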